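The source may hold more compounds than are shown below. What is called first, only, known or untested is meant among the compounds shown, and "the series" means these compounds.

Compound 1 `COc1cccc(CNCCCNc2ccnc3cc(C4CCCCC4)ccc23)c1O` is one of three compounds tested in an ADME assay on HepG2 cells (Homo sapiens) for cytotoxicity, read by luminescence, CellTiter-Glo and ATP content, with a stated time of 72 h; on this read-out higher numbers stand for an effect only at larger amounts of compound and lower numbers for an effect already at smaller amounts. In this assay compound 1 gives 1080 nM, the lowest of the three numbers. Compound 2 `COc1ccc(F)cc1CNCCCNc1ccnc2cc(C3CCCCC3)ccc12` gives 2290 nM in this assay, and compound 3 `COc1ccc(Oc2ccc3c(NCCCNCc4cc(F)ccc4OC)ccnc3c2)cc1` gives 7000 nM. The step of a 2.1-fold higher number from compound 1 to compound 2 (0.33 log units; beyond the scatter) accompanies 5-fluoro-2-methoxyphenyl in place of 2-hydroxy-3-methoxyphenyl on a saturated chain carbon bound to an amine nitrogen, while the step of a 3.1-fold higher number from compound 2 to compound 3 (0.49 log units; beyond the scatter) accompanies 4-methoxyphenoxy in place of cyclohexyl on an aromatic carbon.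

Compound 4 `COc1cccc(CNCCCNc2ccnc3cc(-c4ccccc4)ccc23)c1O` differs from compound 1 in one place: phenyl in place of cyclohexyl on an aromatic carbon. Within the data shown here, no measured step exchanges cyclohexyl for phenyl, so the only guide to a change at this position is the modest step of a 3.1-fold higher number from compound 2 to compound 3 (0.49 log units; beyond the scatter). A step of similar size or smaller, most likely toward a higher number in this assay, is therefore expected, though it could also stay within the scatter. Compound 4 is estimated at 1600 nM, with a range from 700 nM to 4000 nM. This expectation corresponds to a step of a 1.5-fold higher number from compound 1 to compound 4 (0.17 log units; within the scatter).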

Compound 4, half-maximal effective concentration: 3210 nM
Beside the measured number, compound 4's estimate is 2.0-fold (0.30 log units) below it; low and high end bracket the measured number.
By their numbers in this assay, from the lowest: compound 1; then compounds 2 and 4 (each within the scatter of the next); then compound 3.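

In this assay, the exchange of cyclohexyl for phenyl gives a 3.0-fold higher number from compound 1 to compound 4 (0.47 log units; beyond the scatter), even though both groups are six-membered carbon rings with the same count of heavy atoms; whether this ring is aromatic therefore matters at this position. Together with the earlier change from cyclohexyl to 4-methoxyphenoxy, this gives two replacements of cyclohexyl at this aromatic carbon, on two different side chains, and both move the number upward, with no compound shown going against this. Nothing available explains the size or direction of the phenyl step.

The compounds shown leave open how a small group such as methyl, or a nitrogen-containing ring such as pyridyl, would behave at this position. They also leave open whether phenyl would have a similar effect alongside the 5-fluoro-2-methoxyphenyl group of compound 2.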